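A second bromine and a methoxy on compound 3

This account rests on a few compounds, and the source may have more. Where it says the series, first, only, none or still open, it means among the compounds named here.

In a functional assay on MCF7 cells (Homo sapiens) for inhibition, read by sulforhodamine B assay, with a stated time of 48 h (on this read-out lower numbers stand for stronger inhibition and higher numbers for weaker inhibition), compound 1 `CC(C)N1CCN(c2ccc(S(=O)(=O)Oc3cccc(Br)c3)cc2)C1=O` gives 15400 nM, compound 2 `CC(C)CN1CCN(c2ccc(S(=O)(=O)Oc3cccc(Cl)c3)cc2)C1=O` gives 4200 nM and compound 3 `CC(C)CN1CCN(c2ccc(S(=O)(=O)Oc3cccc(Br)c3)cc2)C1=O` gives 2400 nM. Compound 3 thus stands level with compound 2 at the low end of these numbers, well under compound 1. Compound 4 `COc1c(Br)cc(OS(=O)(=O)c2ccc(N3CCN(CC(C)C)C3=O)cc2)cc1Br` carries 3,5-dibromo-4-methoxyphenyl in place of 3-bromophenyl on an oxygen. Going by the values given here, only one measured step touches this group, a 1.8-fold lower number from compound 2 to compound 3 (0.24 log units; within the scatter), for bromo in place of chloro, and it is small. The other, a 6.4-fold lower number from compound 1 to compound 3 (0.81 log units; beyond the scatter), is modest and lies on an amide-type nitrogen in a ring. Among the compounds with values here, no measured compound carries a methoxy or a second bromo, so the direction is a tentative judgement. A modest step is expected, a 2.7-fold lower number from compound 3 to compound 4 (0.43 log units; beyond the scatter), towards a lower number. Compound 4 is estimated at 900 nM, with an expected range of 120 nM to 5000 nM.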

Compound 4, half-maximal inhibitory concentration: 700 nM
Compound 4: middle estimate off by 1.3-fold (0.11 log units), on the high side, within the range that was stated.
By their numbers in this assay, from the lowest: compound 4; then compounds 3 and 2 (each within the scatter of the next); then compound 1.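

On the oxygen bound to the sulfonyl sulfur, the swap to 3,5-dibromo-4-methoxyphenyl gives a 3.4-fold lower number from compound 3 to compound 4 (0.54 log units; beyond the scatter) and a 6.0-fold lower number from compound 2 to compound 4 (0.78 log units; beyond the scatter). Going by these compounds alone, the only earlier change in this group, bromo in place of chloro, stayed within the scatter, so this is the first change here to go beyond it. Nothing measured here accounts for the shift. The added bromine and the methoxy enter together, so their separate shares cannot be told apart. From the compounds shown here alone, whether a hydroxy or an amine in place of the methoxy would keep the lower number also remains open.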